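This account rests on a few compounds, and the source may have more. Where it says the series, first, only, none or still open, it means among the compounds named here.

Compound 1 `N#CC1=C(N)Oc2c(N)cc3nc4ccccc4nc3c2C12C(=O)N(Cc1cnnn1-c1cccc(C(F)(F)F)c1)c1ccccc12` carries a 3-(trifluoromethyl)phenyl on an aromatic nitrogen, and in a functional assay on A549 cells (Homo sapiens) for antiproliferative activity, read by MTT assay, with a stated time of 48 h (a higher number here means a weaker inhibitor, a lower number a stronger inhibitor), compound 1 gives 5400 nM. Compound 2 `CCc1cccc(C)c1-n1nncc1CN1C(=O)C2(C(C#N)=C(N)Oc3c(N)cc4nc5ccccc5nc4c32)c2ccccc21` reaches only the limit of this assay, > 50000 nM. Compound 3 `CCc1cccc(CC)c1-n1nncc1CN1C(=O)C2(C(C#N)=C(N)Oc3c(N)cc4nc5ccccc5nc4c32)c2ccccc21` likewise yields only the limit, > 50000 nM. The steps of an at least 9.2-fold higher number from compound 1 to compound 2 (0.96 log units; beyond the scatter) and an at least 9.2-fold higher number from compound 1 to compound 3 (0.96 log units; beyond the scatter) show that both 2,6-disubstituted phenyls weaken the inhibition; the step that the two limits leave unreadable from compound 2 to compound 3 cannot be read because of the limit of > 50000 nM in this assay, at which 2 of the 3 values shown sit. Compound 3 therefore stands at the weak end of the three values, at the limit shared with compound 2.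

Compound 4 `COc1cc(-n2nncc2CN2C(=O)C3(C(C#N)=C(N)Oc4c(N)cc5nc6ccccc6nc5c43)c3ccccc32)c(OC)cc1Cl` differs from compound 3 by the change (4-chloro-2,5-dimethoxyphenyl in place of 2,6-diethylphenyl on an aromatic nitrogen). For the measured compounds named here, no measured step covers a 4-chloro-2,5-dimethoxyphenyl; the two readable steps only tell that moving away from 3-(trifluoromethyl)phenyl to a 2,6-disubstituted phenyl costs potency, and compound 4 is neither pattern. Compound 4 is therefore expected to fall between compound 1 and the limit, estimated at 20000 nM within 5000 nM to 60000 nM, a step estimated as an at least 2.5-fold lower number from compound 3 to compound 4 (0.39 log units; beyond the scatter).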

Compound 4, half-maximal inhibitory concentration: > 50000 nM
Compound 4: only a limit was reported (the forecaster's own chance of this, stated with the estimate: 40%); middle value at least 2.5-fold (0.39 log units) from the limit.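

The step of an at least 9.2-fold higher number from compound 1 to compound 4 (0.96 log units; beyond the scatter) shows that the loss in this assay is not confined to the two 2,6-disubstituted phenyls: it also appears with 4-chloro-2,5-dimethoxyphenyl on the aromatic nitrogen, a group that carries oxygen and chlorine where 2,6-diethylphenyl has carbon only. For the compounds shown here, of the four compounds, compound 1, with 3-(trifluoromethyl)phenyl, is thus the only one that gives a number rather than a limit. The steps from compound 2 and from compound 3 to compound 4 cannot be read: the limit of > 50000 nM in this assay, at which 3 of the 4 values shown sit.

Still open, going by these compounds, is whether an unsubstituted phenyl, 3-chlorophenyl or 3-methoxyphenyl on this nitrogen would give a number in this assay. Also open, on these data alone, is how an amine or a carboxylic acid on that phenyl would change the result.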